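This account rests on a few compounds, and the source may have more. Where it says the series, first, only, none or still open, it means among the compounds named here.

Compound 1 `CCCn1c(=O)[nH]c2nc(-c3ccc(S(=O)(=O)N4CCN(C)CC4)cc3)[nH]c2c1=O` — in an assay on CHO cells for displacement of a labelled ligand from adenosine receptor A3 (Homo sapiens), read by scintillation counting, with a stated time of 45 min, in the presence of a further agent that is not named here (a lower number here means a stronger inhibitor, a higher number a weaker inhibitor), compound 1 gives > 1000 nM, which is a limit of the assay.
Compound 2 `CCCn1c(=O)[nH]c2nc(-c3ccc(S(=O)(=O)N4CCN(Cc5ccc(Br)cc5)CC4)cc3)[nH]c2c1=O` — in this assay compound 2 gives > 1000 nM, again a limit.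
Compound 3 `CCCn1c(=O)[nH]c2nc(-c3ccc(S(=O)(=O)N4CCN(c5ccccc5Br)CC4)cc3)[nH]c2c1=O` — in this assay compound 3 gives > 1000 nM, also a limit.

Compound 1 therefore stands at the limit, as do both other measured compounds (the limit of > 1000 nM in this assay, at which 3 of the 3 values shown sit). Compound 4 `CCCn1c(=O)[nH]c2nc(-c3ccc(S(=O)(=O)N4CCN(c5ccccc5C)CC4)cc3)[nH]c2c1=O` differs from compound 1 in that (2-methylphenyl in place of methyl on an amine nitrogen in a ring). For the measured compounds named here, the steps that bear on this change, a step that the two limits leave unreadable from compound 1 to compound 3 and a step that the two limits leave unreadable from compound 2 to compound 3, each put a 2-bromophenyl onto the same ring nitrogen, and a step that the two limits leave unreadable from compound 1 to compound 2 puts a 4-bromophenyl nearby; none of the three can be read in size or direction, since every value sits at the limit. With no readable step to build on, compound 4 is expected at 3000 nM, within 1000 nM to 20000 nM. The expected step is thus a step that the limit leaves unreadable from compound 1 to compound 4, most likely reported once more as only a limit.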

Compound 4, inhibition constant: > 1000 nM
Compound 4 was reported as a limit (the forecaster's own chance of this, stated with the estimate: 85%); the middle value lies beyond the limit too.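

For the compounds shown here, compound 4 sits at a limit, as do compound 1, compound 2 and compound 3, so no step among them can be read: the limit of > 1000 nM in this assay, at which 4 of the 4 values shown sit. The compounds shown leave open how far each lies past that limit in this assay, and so whether the group on the amine nitrogen in a ring changes the inhibition constant at all.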